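A few compounds are considered here, and "the series" means these few. Any claim that something is new, unique, unknown or untested is made for them only; others in the source may bear on it.

Compound 1 `CN(C(=O)NC(=O)c1ccc(Cl)cc1Cl)c1nc(C(F)(F)F)c(C(=O)N/N=C/c2cccc(C(F)(F)F)c2)s1` is the point of departure. In a functional assay on HeLa cells (Homo sapiens) for inhibition, read by MTT assay, with a stated time of 72 h (a lower number here means a stronger inhibitor, a higher number a weaker inhibitor), compound 1 gives 9.6 ug/mL. Its nearest neighbour on the numbers shown is compound 2 `CN(C(=O)NC(=O)c1ccc(Cl)cc1Cl)c1nc(C(F)(F)F)c(C(=O)N/N=C/c2ccc(C(F)(F)F)cc2)s1`, which in this assay gives 7.99 ug/mL; the step of a 1.2-fold lower number from compound 1 to compound 2 (0.08 log units; within the scatter) stays within the scatter, so the two cannot be told apart. Compound 3 `CN(C(=O)NC(=O)c1ccc(Cl)cc1Cl)c1nc(C(F)(F)F)c(C(=O)N/N=C/c2cc(C(F)(F)F)cc(C(F)(F)F)c2)s1` carries one further trifluoromethyl on the hydrazone-side ring, and in this assay compound 3 reaches only the limit > 100 ug/mL, a limit of the method rather than a number (the limit of > 100 ug/mL in this assay, at which 1 of the 3 values shown sits). The step of an at least 10-fold higher number from compound 1 to compound 3 (1.01 log units; beyond the scatter) is therefore large.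

Compound 4 `CN(C(=O)NC(=O)c1ccc(C(F)(F)F)cc1)c1nc(C(F)(F)F)c(C(=O)N/N=C/c2cccc(C(F)(F)F)c2)s1` changes a different part of the molecule: 4-(trifluoromethyl)phenyl in place of 2,4-dichlorophenyl on a carbonyl carbon. Neither measured step touches this acyl ring; both concern the ring on the carbon with a double bond to nitrogen. The only lesson they offer is that a trifluoromethyl moved between positions on that ring left the number unchanged, while adding a second one pushed it past the limit. For compound 4 the expectation is a step within the scatter, a 1.6-fold higher number from compound 1 to compound 4 (0.19 log units; within the scatter), with the risk of a weaker result kept in mind. Compound 4 is thus estimated at 15 ug/mL in this assay, within 5 ug/mL to 50 ug/mL.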

Compound 4, half-maximal inhibitory concentration: 6.2 ug/mL
Compound 4: the middle estimate sits 2.4-fold (0.38 log units) above what was measured; the range from low to high includes it.
By their numbers in this assay, from the lowest: compounds 4, 2 and 1 (each within the scatter of the next). At a limit, above all of these: compound 3.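

Compound 4 is the first compound shown with a change on the carbonyl carbon whose other neighbour is an amide-type nitrogen, and in this assay the exchange of 2,4-dichlorophenyl for 4-(trifluoromethyl)phenyl gives a 1.5-fold lower number from compound 1 to compound 4 (0.19 log units; within the scatter) and so leaves the two compounds indistinguishable. For the compounds shown here, this single pair shows that the acyl ring can lose both chlorines and take a trifluoromethyl without a step beyond the scatter, something the earlier compounds could not show, since all of them keep the 2,4-dichlorophenyl. Nothing measured here offers a reason for this outcome.

The compounds shown leave open whether any substituent on this ring matters at all, and whether a plain phenyl, a ring carrying a carboxylic acid or an amine, or a longer alkyl chain in place of the ring would stay within the scatter of compound 1. They also leave open whether the same acyl exchange would give a similar step when made on compound 2, which carries its trifluoromethyl elsewhere on the other ring.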